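This account rests on a few compounds, and the source may have more. Where it says the series, first, only, none or still open, it means among the compounds named here.

Going by the values given here, in a functional assay on the whole organism with Rattus norvegicus as the target (a lower number here means that less compound is needed, a higher number that more compound is needed for the effect), compound 1 `O=C(O)c1cc(-c2ccccc2)ccc1O` gives 54 mg/kg and stands lowest of the two numbers so far, while compound 2 `CC(=O)Oc1ccc(-c2ccccc2)cc1C(=O)O` gives 170 mg/kg as its acetyl counterpart. Compound 3 `O=C(O)c1cc(-c2cccc(F)c2)ccc1O` departs from compound 1 by fluoro in place of hydrogen on an aromatic carbon and remains unmeasured. Among the compounds with values here, the only measured step of a 3.1-fold higher number from compound 1 to compound 2 (0.50 log units; beyond the scatter) is modest and beyond the scatter, but it concerns a different change on an oxygen, so it bears only loosely and gives no direction here. A small change is therefore expected, possibly within the scatter. The expected step of a 1.2-fold lower number from compound 1 to compound 3 (0.08 log units; within the scatter) is only a rough estimate. The estimate for compound 3 is 45 mg/kg with an expected range from 15 mg/kg to 130 mg/kg for now.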

Compound 3, dose for half-maximal effect: 40 mg/kg
Compound 3: the middle estimate sits 1.1-fold (0.05 log units) above what was measured, within the range that was stated.
By their numbers in this assay, from the lowest: compounds 3 and 1 (each within the scatter of the next); then compound 2.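

In this assay, fluoro in place of hydrogen on an aromatic carbon, meta to a large group, gives a 1.4-fold lower number from compound 1 to compound 3 (0.13 log units; within the scatter), so this position accepts a fluoro with the number staying within the scatter. The acetyl change on the oxygen, by contrast, gave a 3.1-fold higher number from compound 1 to compound 2 (0.50 log units; beyond the scatter). No available evidence bears on the reason for this result. On these data alone, whether a bulkier group at the same position, such as trifluoromethyl or methoxy, or an amine, would stay within the scatter remains open. So does whether fluoro elsewhere on that ring would behave the same way.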